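A Halogen Exchange on the Shared Core

A few compounds are considered here, and "the series" means these few. Any claim that something is new, unique, unknown or untested is made for them only; others in the source may bear on it.

Of the compounds shown here, two have been measured in a functional assay on PC-12 cells (Rattus norvegicus) for cytotoxicity, read by MTT assay, with stated times of 3 h and 2 h, tested at 0.1 uM; on this read-out lower numbers stand for a weaker effect and higher numbers for a stronger effect at the one concentration tested. Compound 1 `COc1ccc(-c2cc3ccc(OCCCCn4cc(CNC(=O)CCCCC5CCSS5)nn4)cc3oc2=O)cc1` gives 32.1% in this assay, and compound 2 `O=C(CCCCC1CCSS1)NCc1cn(CCCCOc2ccc3cc(-c4ccc(Br)cc4)c(=O)oc3c2)nn1` gives 34.2%. Among the measured compounds shown here, the single step between them, a number 2.1 percentage points higher from compound 1 to compound 2 (within the scatter), alters only the group on the aromatic carbon. Compound 2 carries the higher of the two numbers, yet its nearest neighbour, compound 1, lies within the scatter of it, so no order between them can be claimed. Compound 3 `O=C(CCCCC1CCSS1)NCc1cn(CCCCOc2ccc3cc(-c4ccc(Cl)c(Cl)c4)c(=O)oc3c2)nn1` has not yet been measured; it differs from compound 2 by 3,4-dichlorophenyl in place of 4-bromophenyl on an aromatic carbon. For the measured compounds named here, the only measured step that bears on this change is the exchange of one group on that same aromatic carbon, which stayed within the scatter. On that basis a step of about a number 0.8 percentage points higher from compound 2 to compound 3 (within the scatter) in this assay is expected, nothing beyond the scatter. Compound 3 is therefore estimated at 35%, between 25% and 46%.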

Compound 3, a percentage reported as activity, at one concentration (the size of the read-out at that concentration, not a potency): 39.6%
For compound 3 the middle estimate is 4.6 percentage points below the measured one, and the stated range covers the measured number.
By their numbers in this assay, from the lowest: compounds 1, 2 and 3 (each within the scatter of the next).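

In this assay, 3,4-dichlorophenyl in place of 4-bromophenyl gives a number 5.4 percentage points higher from compound 2 to compound 3 (within the scatter) and the same group in place of 4-methoxyphenyl gives a number 7.5 percentage points higher from compound 1 to compound 3 (within the scatter). The earlier pair had shown only one exchange of a single substituent on the phenyl ring at this aromatic carbon; this result adds a ring carrying two chlorine atoms, and all three rings still lie within the scatter of one another, so no order among them can be claimed. No accompanying measurement bears on this result. Still open, on these data alone, is whether a phenyl ring carrying an amine or a carboxylic acid at this carbon would give a step beyond the scatter. Also open, as far as these compounds go, is whether a longer chain between the shared core and the lipoamide end would move the number in this assay.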